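The source may report more compounds than this note shows. Statements on the series, on what has been measured and on what is new or still open speak of the compounds shown alone.

Measured compounds, antiproliferative read-out:

- compound 1 `O=C(CCCCCCn1cc(Nc2ncc(Cl)c(Nc3ccc(F)cc3)n2)cn1)NO` gives 120 nM in a functional assay on Jurkat cells (Homo sapiens) for antiproliferative activity, read by MTT assay, with a stated time of 48 h; on this read-out lower numbers stand for stronger inhibition and higher numbers for weaker inhibition
- compound 2 `O=C(CCCCCn1cc(Nc2ncc(Cl)c(Nc3ccc(F)cc3)n2)cn1)NO` gives 60 nM in this assay
- compound 3 `O=C(CCCCCn1cc(Nc2ncc(Cl)c(Nc3ccc(Cl)cc3)n2)cn1)NO` gives 60 nM in this assay

Compound 1 stands at the highest of the three numbers in this assay, but its nearest neighbour compound 2 and its furthest neighbour compound 3 both sit within the scatter of it, so the three measured compounds are not separable on these data. The step from the longer to the shorter chain reads a 2.0-fold lower number from compound 1 to compound 2 (0.30 log units; within the scatter), and the halogen swap on the aromatic carbon reads no change at the digits printed from compound 2 to compound 3 (within the scatter).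

Compound 4 `O=C(CCCCCCn1cc(Nc2ncc(Cl)c(NC3CC3)n2)cn1)NO` is not yet measured. From compound 1 it differs by cyclopropyl in place of 4-fluorophenyl on a nitrogen on an aromatic ring. Among the compounds with values here, neither measured step touches this position: both concern the chain or the halogen on the aromatic ring that leaves, so no step in this assay bears on the change. The expectation for compound 4 therefore rests on nothing firmer than the shared core and the retained chain, and a step of a 2.9-fold higher number from compound 1 to compound 4 (0.46 log units; beyond the scatter) is estimated, in the direction of a weaker number, with wide uncertainty. Compound 4 is expected to give about 350 nM, within 80 nM to 1500 nM.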

Compound 4, half-maximal inhibitory concentration: 50 nM
The estimate for compound 4 lay 7.0-fold (0.85 log units) above the measured number, and the stated range ends above it.
By their numbers in this assay, from the lowest: compounds 4, 2, 3 and 1 (each within the scatter of the next, the first and the last beyond it).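

Swapping 4-fluorophenyl for cyclopropyl on the nitrogen is the first single change in the series whose step lies beyond the scatter: a 2.4-fold lower number from compound 1 to compound 4 (0.38 log units; beyond the scatter) in this assay is modest but readable. The aromatic ring at this position can therefore be given up without loss on this read-out, with a three-membered non-aromatic carbon ring of 3 heavy atoms standing in for a group of 7. No measurement bears on why the number moves this way.

Going by these compounds, whether the cyclopropylamino group acts the same way on the shorter chain of compound 2 remains open. Also open, on these data alone, is how far this position extends to other groups on the nitrogen, such as isopropyl, cyclohexyl or a benzyl group.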